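This account rests on a few compounds, and the source may have more. Where it says the series, first, only, none or still open, it means among the compounds named here.

Measured so far:
compound 1 `Cc1onc(-c2c(F)cccc2Cl)c1C(=O)Nc1c(-c2ccccc2)[nH]c2ccccc12` — 9000 nM
compound 2 `O=C(CSCc1ccccc1)Nc1c(-c2ccccc2)[nH]c2ccccc12` — 30000 nM
compound 3 `OC1CCCN(C(=S)Sc2c(-c3ccc(Br)cc3)[nH]c3ccc(Cl)cc23)C1` — 29000 nM

In a functional assay on A549 cells (Homo sapiens) for inhibition, read by MTT assay, with a stated time of 72 h (a higher number here means a weaker inhibitor of growth, a lower number a stronger inhibitor of growth), compound 3 stands second highest of the three numbers. Its nearest neighbour is compound 2, whose value lies within the scatter of it; the furthest is compound 1, whose lower number lies beyond the scatter. Compound 4 `OC1CCCN(C(=S)Sc2c(-c3ccc(Br)cc3)[nH]c3ccccc23)C1` awaits measurement in this assay. Its change from compound 3: hydrogen in place of chloro on an aromatic carbon. Among the measured compounds shown here, no pair of measured compounds shows this change, so there is no measured step to lean on. The expected step in this assay is small, probably none beyond the scatter, with a slight lean toward a higher number. Compound 4 is expected to give 35000 nM, in the range 12000 nM to 100000 nM, meaning an expected step of a 1.2-fold higher number from compound 3 to compound 4 (0.08 log units; within the scatter).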

Compound 4, concentration for 50% growth inhibition: 24000 nM
For compound 4 the middle estimate is 1.5-fold (0.16 log units) above the measured one, within the range that was stated.
By their numbers in this assay, from the lowest: compound 1; then compounds 4, 3 and 2 (each within the scatter of the next).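

In this assay, hydrogen in place of chloro on this aromatic carbon of the fused system gives a 1.2-fold lower number from compound 3 to compound 4 (0.08 log units; within the scatter). Among the compounds shown here, for this pair, the chloro is therefore not needed to keep the growth inhibition seen, and this is the first one-place comparison. Nothing measured bears on why the two compounds read alike.

As far as these compounds go, whether an amine or a methoxy group on this carbon would give a step beyond the scatter stays open. Also open, from the compounds shown here alone, is whether this change reads the same on the amide compounds' core.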